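This account rests on a few compounds, and the source may have more. Where it says the series, first, only, none or still open, it means among the compounds named here.

Measured in a functional assay on MDA-MB-231 cells (Homo sapiens) for cytotoxicity, read by MTT assay, with a stated time of 48 h; a higher number here means a weaker inhibitor, a lower number a stronger inhibitor:
compound 1 `O=C(NCCCCC(c1ccc(F)cc1)c1ccc(F)cc1)Nc1ccc([N+](=O)[O-])cc1`: 6470 nM
compound 2 `O=C(NCCCCC(c1ccc(F)cc1)c1ccc(F)cc1)Nc1cccc(C(F)(F)F)c1`: 3380 nM
compound 3 `O=C(NCCCCC(c1ccc(F)cc1)c1ccc(F)cc1)Nc1cccc(Cl)c1`: 5070 nM

These three compounds share one core and differ only in the substituted phenyl on an amide-type nitrogen. Compound 3 stands within the scatter of both others, as shown by a 1.3-fold lower number from compound 1 to compound 3 (0.11 log units; within the scatter) and a 1.5-fold higher number from compound 2 to compound 3 (0.18 log units; within the scatter). No order can therefore be drawn among them at this position.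

The next compound, compound 4 `O=C(NCCCCC(c1ccc(F)cc1)c1ccc(F)cc1)Nc1ccc(Cl)c(C(F)(F)F)c1`, keeps the core and changes that group: 4-chloro-3-(trifluoromethyl)phenyl in place of 3-chlorophenyl on an amide-type nitrogen. In words, 4-chloro-3-(trifluoromethyl)phenyl stands in place of 3-chlorophenyl on an amide-type nitrogen. Among the compounds with values here, no measured step makes this exact change. The closest evidence is the exchange of chloro and trifluoromethyl in a 1.5-fold higher number from compound 2 to compound 3 (0.18 log units; within the scatter), together with a 1.9-fold lower number from compound 1 to compound 2 (0.28 log units; within the scatter). Both are small, and among these three compounds no change of the phenyl has gone beyond the scatter.

In this assay, no step beyond the scatter is therefore expected. A slight move towards a lower number is possible, since compound 2, which also carries a trifluoromethyl, gives 3380 nM. The expected step is a 1.7-fold lower number from compound 3 to compound 4 (0.23 log units; within the scatter). Compound 4 is expected at 3000 nM, with an estimated range from 1300 nM to 6500 nM.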

Compound 4, half-maximal inhibitory concentration: 3150 nM
Compound 4: the middle estimate sits 1.1-fold (0.02 log units) below what was measured; the range from low to high includes it.
By their numbers in this assay, from the lowest: compounds 4, 2, 3 and 1 (each within the scatter of the next, the first and the last beyond it).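

In this assay, adding chloro to the phenyl of compound 2 leaves the number practically unmoved, with a 1.1-fold lower number from compound 2 to compound 4 (0.03 log units; within the scatter), and adding trifluoromethyl to the phenyl of compound 3 also stays small, with a 1.6-fold lower number from compound 3 to compound 4 (0.21 log units; within the scatter), so neither addition on its own is shown to matter at this position. What is new is that the series now holds its first step beyond the scatter, a 2.1-fold lower number from compound 1 to compound 4 (0.31 log units; beyond the scatter), although that step is modest and links only the two ends of a chain of compounds, each within the scatter of the next, so 4-chloro-3-(trifluoromethyl)phenyl can be set apart from 4-nitrophenyl alone and not from the other two groups. The data offer no independent measurement that would explain even this small difference.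

On these data alone, all four compounds keep a phenyl bearing only nitro, chloro or trifluoromethyl on the amide-type nitrogen, so it remains open whether an amine or a carboxylic acid on that phenyl would move the number further. As far as these compounds go, the effect of a longer chain in the shared core also remains open, as does whether any of these small differences would hold in a second cell line.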